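A few compounds are considered here, and "the series" means these few. Any claim that something is new, unique, unknown or untested is made for them only; others in the source may bear on it.

In a functional assay on HUVEC cells (Homo sapiens) (a higher number here means that more compound is needed for the effect, a lower number that less compound is needed), compound 2 `COC1=C(C)C(=O)/C(=C(O)/C=C/c2ccco2)C(=O)C1(C)C` stands at < 4 ug/mL, which is a limit and not a number. Compound 1 `COC1=C(C)C(=O)/C(=C(O)/C=C/c2cccc(OC)c2)C(=O)C1(C)C` gives < 4 ug/mL, likewise a limit. Compound 3 `COC1=C(C)C(=O)/C(=C(O)/C=C/c2nccs2)C(=O)C1(C)C` carries 1,3-thiazol-2-yl in place of furan-2-yl on a double-bonded chain carbon bound to a double-bonded chain carbon. For the measured compounds named here, the one measured step that bears on this change, a step that the two limits leave unreadable from compound 1 to compound 2, has no readable size, and both compounds rest at the limit of < 4 ug/mL in this assay, at which 2 of the 2 values shown sit. No size or direction can be carried over to this assay, so no change beyond the scatter is expected. The expected step is a step that the limit leaves unreadable from compound 2 to compound 3. For compound 3 the estimate is 2 ug/mL, with an expected range from 0.5 ug/mL to 8 ug/mL.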

Compound 3, concentration for half-maximal effect: < 4 ug/mL
Compound 3 was reported as a limit; the forecaster's own chance of this, stated with the estimate: 65%; the middle value does not contradict the limit.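

No step can be read among compound 1, compound 2 and compound 3 in this assay, since all three rest at one limit: the limit of < 4 ug/mL in this assay, at which 3 of the 3 values shown sit.

The compounds shown leave open whether 3-methoxyphenyl, furan-2-yl and 1,3-thiazol-2-yl differ at all in this assay.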